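Amide substituent change in a bromo-aza series on MCF7 cells

The compounds below may be only part of what the source reports. "The series", "measured", "known", "first", "only" and "open" are said of these compounds alone.

The series is anchored by compound 1 `CN(C)c1ccc(CNC(=O)c2nc(Br)c3cccnc3c2N[C@H]2CC[C@H](N)CC2)cc1`, which in a functional assay on MCF7 cells (Homo sapiens) for cytotoxicity, read by MTT assay, with a stated time of 72 h (on this read-out higher numbers stand for weaker inhibition and lower numbers for stronger inhibition), gives 5000 nM. Compound 2 `C[C@H](NC(=O)c1nc(Br)c2cccnc2c1N[C@H]1CC[C@H](N)CC1)c1ccc(F)cc1` shares the same core, but in this assay compound 2 gives "not determined" (no result reported), so it stands on no number. Compound 3 `N[C@H]1CC[C@H](Nc2c(C(=O)NCc3cccc(C(F)(F)F)c3)nc(Br)c3cccnc23)CC1` differs from compound 2 in one place, (3-(trifluoromethyl)benzyl in place of 1-(4-fluorophenyl)ethyl on an amide-type nitrogen). Within the data shown here, with no measured step available for this change, the only anchor is compound 1 with 5000 nM, and a step of no more than the usual scatter is expected in either direction. Compound 3 is therefore estimated at 5000 nM in this assay, within a range of 1500 nM to 15000 nM.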

Compound 3, half-maximal inhibitory concentration: 15000 nM
Estimate against measurement, compound 3: 3.0-fold (0.48 log units) below; low and high end bracket the measured number.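

In this assay, the substituent on the amide-type nitrogen now has a first readable step: 3-(trifluoromethyl)phenyl in place of 4-(dimethylamino)phenyl gives weaker inhibition (a 3.0-fold higher number from compound 1 to compound 3 (0.48 log units; beyond the scatter)), beyond the scatter, so the result at this position depends on the aryl group it carries. The step from compound 2 to compound 3 cannot be read, as compound 2 has no number. Nothing measured here accounts for this step.

On these data alone, it remains open whether the step follows the substituent itself or where it sits on the ring. As far as these compounds go, how an unsubstituted benzyl, a ring carboxylic acid or a longer chain would read also remains open.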